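Adding methoxymethoxy to a compound at the assay limit

The source may hold more compounds than are shown below. What is called first, only, known or untested is meant among the compounds shown, and "the series" means these compounds.

In an ADME assay on ECV-304 cells (Homo sapiens) for cytotoxicity, read by MTT assay, with a stated time of 72 h (a higher number here means a weaker inhibitor, a lower number a stronger inhibitor), compound 1 (`COc1ccc(C2=C(c3cc(OC)c(OC)c(OC)c3)C(=O)CC2O[SiH2]C(C)(C)C)cc1`) gives > 100 ug/mL as a limit, not a number. Compound 2 (`COc1ccc(C2=C(c3cc(OC)c(OC)c(OC)c3)C(=O)CC2O)cc1`) likewise gives > 100 ug/mL as a limit. The evidence so far is the limit of > 100 ug/mL in this assay, at which 2 of the 2 values shown sit, and nothing more. Compound 3 (`COCOc1cc(C2=C(c3cc(OC)c(OC)c(OC)c3)C(=O)CC2O[SiH2]C(C)(C)C)ccc1OC`) differs from compound 1 by methoxymethoxy in place of hydrogen on an aromatic carbon in one place, where methoxymethoxy replaces hydrogen on an aromatic carbon. Going by the values given here, with a step that the two limits leave unreadable from compound 1 to compound 2 as the only measured guide, no step beyond the scatter is expected in this assay in either direction. The expected step is a number no higher from compound 1 to compound 3 (the limit leaves the size open) on this reading. Compound 3 is estimated at 100 ug/mL with a range from 30 ug/mL to 200 ug/mL in this measurement.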

Compound 3, half-maximal inhibitory concentration: 40 ug/mL
Compound 3: middle estimate off by 2.5-fold (0.40 log units), on the high side; the measured number falls inside the stated range.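

In this assay, methoxymethoxy on the aromatic carbon ortho to the methoxy group gives an at least 2.5-fold lower number from compound 1 to compound 3 (0.39 log units; beyond the scatter). Going by these compounds alone, this is the first readable change, and it shows that this ring position can affect the read-out; the step between compound 1 and compound 2 cannot be read. Its true size stays open, as compound 3 alone has an exact number: the limit of > 100 ug/mL in this assay, at which 2 of the 3 values shown sit.

An amine or a longer chain at this position could give a different result. Going by these compounds, whether methoxymethoxy would lower the number for compound 2 also remains open.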